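From Bromo to Methoxycarbonyl on Compound 1

The source may hold more compounds than are shown below. What is called first, only, known or untested is meant among the compounds shown, and "the series" means these compounds.

In a functional assay on NB-4 cells (Homo sapiens) for cytotoxicity, read by CCK-8 assay, with a stated time of 24 h (a lower number here means a stronger inhibitor, a higher number a weaker inhibitor), three compounds sharing one core have been measured. Compound 1 (`C=CC(=O)N1C(=O)CC(c2ccc(Br)cc2)Sc2ccccc21`) gives 59400 nM, the second highest of the three numbers. Compound 2 (`C=CC(=O)N1C(=O)CCSc2ccccc21`) gives 22400 nM, and compound 3 (`C=CC(=O)N1C(=O)CC(c2cccs2)Sc2ccccc21`) gives 765000 nM.

Compound 4 (`C=CC(=O)N1C(=O)CC(c2ccc(C(=O)OC)cc2)Sc2ccccc21`) has not yet been measured. It differs from compound 1 in one place: methoxycarbonyl in place of bromo on an aromatic carbon. This is methoxycarbonyl in place of bromo on an aromatic carbon, para to a large group.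

Among the compounds with values here, no measured step makes this exact change, so the evidence is indirect. Hydrogen in place of the whole 4-bromophenyl group gave a 2.7-fold lower number from compound 1 to compound 2 (0.42 log units; beyond the scatter), a modest step. Thiophen-2-yl in place of 4-bromophenyl gave a 13-fold higher number from compound 1 to compound 3 (1.11 log units; beyond the scatter), a large step. Both replaced the entire group, whereas compound 4 keeps its six-membered ring and changes only one substituent. Within the data shown here, a smaller step is therefore expected, probably not beyond the usual scatter, with a slight lean upward since the one ring swap gave a higher number. The expected change is a 1.3-fold higher number from compound 1 to compound 4 (0.13 log units; within the scatter). Compound 4 is estimated at 80000 nM, with an expected range of 25000 nM to 260000 nM.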

Compound 4, half-maximal inhibitory concentration: 24400 nM
Compound 4: the middle estimate sits 3.3-fold (0.52 log units) above what was measured; measured number outside the range, below it.
By their numbers in this assay, from the lowest: compounds 2 and 4 (each within the scatter of the next); then compound 1; then compound 3.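

In this assay, within the data shown here, the earlier steps replaced the whole group on the saturated ring carbon, whereas this change keeps the six-membered aromatic ring and alters only the substituent para to a large group. Putting methoxycarbonyl in place of bromo gives a 2.4-fold lower number from compound 1 to compound 4 (0.39 log units; beyond the scatter), so a change at this one aromatic carbon is enough to move the number beyond the scatter. Compound 4 at 24400 nM and compound 2 at 22400 nM lie within the scatter of each other, so a substituted phenyl on the saturated ring carbon need not leave a number apart from that of hydrogen there, although 4-bromophenyl and thiophen-2-yl do; nothing shown here explains this shift.

The compounds shown leave open whether the shift belongs to the methoxycarbonyl group itself, or whether a carboxylic acid, an amide or a nitrile at the same carbon would give a similar number. They also leave open where a plain phenyl group, with hydrogen at that carbon, would fall, which would help separate what bromo does from what methoxycarbonyl does.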